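The source may hold more compounds than are shown below. What is called first, only, known or untested is meant among the compounds shown, and "the series" means these compounds.

Three compounds built on one shared core were tested in a functional assay on MCF7 cells (Homo sapiens) for cytotoxicity, read by MTT assay, with a stated time of 24 h, tested at 32 ug/mL; a lower number here means a weaker effect, a higher number a stronger effect of the compound at the concentration tested. Compound 1 `Cn1c(-c2ccc(NC(=O)CSc3nc4ccccc4s3)cc2)nc(-c2ccccc2)c1-c1ccccc1` gives 59% in this assay. Compound 2 `Cn1cnnc1SCC(=O)Nc1ccc(-c2nc(-c3ccccc3)c(-c3ccccc3)n2C)cc1` gives 89.2%. Compound 3 `Cn1c(-c2ccc(NC(=O)CSC3=NCCS3)cc2)nc(-c2ccccc2)c1-c1ccccc1` gives 52.5%, the lowest of the three numbers; its nearest neighbour is compound 1, within the scatter, and its furthest is compound 2, beyond the scatter. Among these three there was a number 30.2 percentage points higher from compound 1 to compound 2 (beyond the scatter), there was a number 36.7 percentage points lower from compound 2 to compound 3 (beyond the scatter), and there was a number 6.5 percentage points lower from compound 1 to compound 3 (within the scatter). So exchanging the ring on the sulfur can shift the number strongly or hardly at all.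

Compound 4 `CCN1CCN(CC(=O)Nc2ccc(-c3nc(-c4ccccc4)c(-c4ccccc4)n3C)cc2)CC1` has not yet been measured. It differs from compound 3 by a group of 8 heavy atoms (6 carbon, 2 nitrogen; one six-membered non-aromatic ring with 2 hetero atoms) in place of a group of 6 heavy atoms (3 carbon, 1 nitrogen, 2 sulfur; one five-membered non-aromatic ring with 2 hetero atoms), on a saturated chain carbon bound to a carbonyl carbon. The measured steps all kept a sulfur-linked ring and only swapped one ring for another; here the whole group containing the sulfur leaves and 4-ethylpiperazin-1-yl enters, so none of them bears directly on this change. They show only that this part of the molecule is where the numbers moved most. On that basis the step of a number 7.5 percentage points higher from compound 3 to compound 4 (within the scatter) is expected to be small, with its direction uncertain. Compound 4 is therefore expected to give about 60% in this assay, within a wide range from 35% to 88%.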

Compound 4, a percentage reported as activity, at one concentration (the size of the read-out at that concentration, not a potency): 38.6%
Beside the measured number, compound 4's estimate is 21.4 percentage points above it, and the stated range covers the measured number.
By their numbers in this assay, from the lowest: compound 4; then compounds 3 and 1 (each within the scatter of the next); then compound 2.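

Putting 4-ethylpiperazin-1-yl on the saturated chain carbon bound to a carbonyl carbon, in place of a sulfur-linked ring, lowers the number in this assay against all three earlier compounds: there is a number 13.9 percentage points lower from compound 3 to compound 4 (beyond the scatter), a number 20.4 percentage points lower from compound 1 to compound 4 (beyond the scatter) and a number 50.6 percentage points lower from compound 2 to compound 4 (beyond the scatter) here. The earlier steps shown here swapped only the ring on the sulfur and could not separate compound 1 from compound 3, whereas this change, which removes the sulfur as well, places compound 4 lowest of the four, beyond the scatter of each of the others. It also shows that the step is large against compound 2 and modest against compounds 1 and 3, so the size of the fall depends on which sulfur-linked group is replaced, and no measurement shown here explains why the number falls.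

Because the sulfur and the ring change together, these compounds leave open whether the fall follows the loss of the sulfur, the piperazine ring or its ethyl group. A morpholin-4-yl group or a plain diethylamino group at this place would help to separate these possibilities, and readings at further concentrations would show whether the same order holds as a measure of potency.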